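A few compounds are considered here, and "the series" means these few. Any claim that something is new, unique, unknown or untested is made for them only; others in the source may bear on it.

Compound 2 `CCCS(=O)(=O)Nc1ccc(F)c(C(=O)c2n[nH]c3ncc(-c4ccc(OC)cc4Cl)cc23)c1F` has been measured in an assay for binding affinity to dual specificity mitogen-activated protein kinase kinase 4 (Homo sapiens), read by KINOMEscan, tested at 100 nM (on this read-out higher numbers stand for a weaker effect at the one concentration tested and lower numbers for a stronger effect), and gives 5.3%. For the measured compounds named here, its only measured neighbour is compound 1 `CCCS(=O)(=O)Nc1ccc(F)c(C(=O)c2n[nH]c3ncc(-c4cccc(O)c4)cc23)c1F`, which in this assay gives 2.2%; the two numbers lie within the scatter of each other, so they do not separate the two compounds. Compound 3 `CCCS(=O)(=O)Nc1ccc(F)c(C(=O)c2n[nH]c3ncc(-c4ccc(S(C)(=O)=O)cc4)cc23)c1F` has not yet been measured. It differs from compound 2 in one place: 4-(methylsulfonyl)phenyl in place of 2-chloro-4-methoxyphenyl on an aromatic carbon. Going by the values given here, the one measured step that bears on this exchanged the group on the same aromatic carbon of the shared core, a number 3.1 percentage points higher from compound 1 to compound 2 (within the scatter), and that exchange stayed within the scatter. Exchanging the aromatic group at that carbon therefore left the read-out essentially unchanged once, and no step beyond the scatter is expected here either, with a number 0.7 percentage points higher from compound 2 to compound 3 (within the scatter) as the expected move in this assay. Compound 3 is accordingly estimated at 6%, between 0.5% and 25%.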

Compound 3, a percentage reported as activity, at one concentration (the size of the read-out at that concentration, not a potency): 1.5%
The estimate for compound 3 lay 4.5 percentage points above the measured number; measured number inside the range.
By their numbers in this assay, from the lowest: compounds 3, 1 and 2 (each within the scatter of the next).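

A third aromatic group at this carbon, para to a fused ring, again gives no separation in this assay: the step is a number 3.8 percentage points lower from compound 2 to compound 3 (within the scatter), and against the 3-hydroxyphenyl compound it is a number 0.7 percentage points lower from compound 1 to compound 3 (within the scatter). Where the earlier pair showed a single exchange within the scatter, three different substituted phenyl groups now cannot be told apart, so in these compounds the read-out does not follow the choice among 3-hydroxyphenyl, 2-chloro-4-methoxyphenyl and 4-(methylsulfonyl)phenyl. No measurement shown here offers an explanation for this result.

From the compounds shown here alone, all three groups are six-membered aromatic rings of carbon only, so it remains open whether a pyridine ring, a morpholine or a plain methyl group at this carbon would give a similar number. Going by these compounds, the rest of the molecule is identical throughout, so the effect of changing it also stays unknown.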